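The source may hold more compounds than are shown below. What is called first, only, known or untested is meant among the compounds shown, and "the series" means these compounds.

Working notes on the series. Compound 3 `Cc1ccc(-c2nc(CNc3ccc(C(=O)NO)cc3)n(-c3ccccc3)n2)s1` stands highest of the three numbers in an assay on Sf9 cells for inhibition of protein deacetylase HDAC6 (Homo sapiens), read by fluorescence, with a stated time of 40 min, tested at 100 nM (a lower number here means less inhibition, a higher number more inhibition at the concentration tested (going by the name of the read-out)), where compound 3 gives 79.7%. Compound 1 `O=C(NO)c1ccc(NCc2nc(-c3ccc(Br)o3)nn2-c2ccccc2)cc1` gives 55.8% and compound 2 `O=C(NO)c1ccc(NCc2nc(-c3ccc(Br)cc3)nn2-c2ccccc2)cc1` gives 54.7%; the step of a number 1.1 percentage points lower from compound 1 to compound 2 (within the scatter) is within the scatter, while a number 23.9 percentage points higher from compound 1 to compound 3 (beyond the scatter) and a number 25 percentage points higher from compound 2 to compound 3 (beyond the scatter) are both modest gains. Compound 4 `O=C(NO)c1ccc(NCc2nc(-c3ccncc3)nn2-c2ccccc2)cc1` differs from compound 3 by pyridin-4-yl in place of 5-methylthiophen-2-yl on an aromatic carbon. Going by the values given here, no measured step bears directly on a pyridin-4-yl; the only other six-membered ring at this position, the 4-bromophenyl of compound 2, sits well below compound 3. A drop of about a number 22.7 percentage points lower from compound 3 to compound 4 (beyond the scatter) is therefore expected, back toward the level of compounds 1 and 2. Compound 4 is estimated at 57%, within 38% to 74%.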

Compound 4, a percentage reported as inhibition, at one concentration (the size of the read-out at that concentration, not a potency): 30.8%
For compound 4 the middle estimate is 26.2 percentage points above the measured one, and the stated range ends above it.
By their numbers in this assay, from the lowest: compound 4; then compounds 2 and 1 (each within the scatter of the next); then compound 3.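

Replacing 5-methylthiophen-2-yl with pyridin-4-yl gives by far the largest change yet seen at this position: a number 48.9 percentage points lower from compound 3 to compound 4 (beyond the scatter) in this assay. Ring size alone does not set the level, since the six-membered pyridin-4-yl still differs from the six-membered 4-bromophenyl, with a number 23.9 percentage points lower from compound 2 to compound 4 (beyond the scatter) as the step. The 5-bromofuran-2-yl also stands clear of pyridin-4-yl, with a number 25 percentage points lower from compound 1 to compound 4 (beyond the scatter) as the step, and no measurement here explains these steps.

Open, from the compounds shown here alone, is whether a pyridin-3-yl or an unsubstituted thiophen-2-yl would sit nearer compound 3 or compound 4.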